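The compounds below may be only part of what the source reports. "The series", "measured", "known", "first", "only" and "open" are said of these compounds alone.

In an ADME assay on BJ cells (Homo sapiens) for cytotoxicity, with a stated time of 72 h (on this read-out higher numbers stand for an effect only at larger amounts of compound and lower numbers for an effect already at smaller amounts), compound 1 `CCc1ccc(-c2nc3c(c(C)nn3-c3ccccc3)c(-c3ccccc3F)c2C#N)cc1` gives > 20000 nM, which is a limit and not a number. Compound 2 `CCc1ccc(-c2nc3c(c(C)nn3-c3ccccc3)c(-c3cccc(O)c3)c2C#N)cc1` gives > 20000 nM, which is also a limit. The series therefore stands at the limit of > 20000 nM in this assay, at which 2 of the 2 values shown sit, and compound 2 has no exact value from which to measure a change. Compound 3 `CCc1ccc(-c2nc3c(c(C)nn3-c3ccccc3)c(-c3ccc(O)cc3)c2C#N)cc1` keeps the same atoms as compound 2 but joins them differently: 4-hydroxyphenyl in place of 3-hydroxyphenyl on an aromatic carbon. It carries 4-hydroxyphenyl in place of 3-hydroxyphenyl on the aromatic carbon opposite the ring nitrogen. Among the compounds with values here, only one measured step bears on this change, a step that the two limits leave unreadable from compound 1 to compound 2, which altered the group on that same carbon and gives no size to carry over. In this assay, a step that the limit leaves unreadable from compound 2 to compound 3 is therefore expected to stay within the scatter, and another limit is the likeliest report. For compound 3 the estimate is 22000 nM, with an expected range of 10000 nM to 40000 nM.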

Compound 3, half-maximal effective concentration in the BJ assay: > 20000 nM
Compound 3 ended at the assay's limit (the forecaster's own chance of this, stated with the estimate: 85%); the middle value lies beyond the limit too.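

Within the data shown here, compound 1, compound 2 and compound 3 all give only a limit in the BJ assay, and no step between them can be read: the limit of > 20000 nM in the BJ assay, at which 3 of the 3 values shown sit. The compounds shown leave open whether 2-fluorophenyl, 3-hydroxyphenyl and 4-hydroxyphenyl differ at all in half-maximal effective concentration. In a physicochemical assay for solubility, read by spectrophotometry, in phosphate buffer, with a stated time of 18 h, at pH 7.4 (a lower number here means a less soluble compound, a higher number a more soluble compound), compound 2 gives 18000 nM and compound 3 gives 5700 nM, a 3.2-fold lower number from compound 2 to compound 3 (0.50 log units; beyond the scatter), with 4-hydroxyphenyl in place of 3-hydroxyphenyl.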